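Compound 3: a 2-fluorophenyl swap on a weak series

The source may hold more compounds than are shown below. What is called first, only, known or untested is meant among the compounds shown, and "the series" means these compounds.

In a functional assay on MDA-MB-231 cells (Homo sapiens) for antiproliferative activity, read by MTT assay, with a stated time of 24 h (on this read-out higher numbers stand for weaker inhibition and lower numbers for stronger inhibition), compound 1 `Cc1ccccc1NNC(=O)c1ccccc1NS(=O)(=O)c1cnc(O)nc1O` gives > 20000 nM, which is a limit and not a number. For the measured compounds named here, compound 2 `O=C(NNc1cccc(Cl)c1)c1ccccc1NS(=O)(=O)c1cnc(O)nc1O` gives 11800 nM, the only actual number so far. Compound 3 `O=C(NNc1ccccc1F)c1ccccc1NS(=O)(=O)c1cnc(O)nc1O` differs from it as follows: 2-fluorophenyl in place of 3-chlorophenyl on an amine nitrogen. This puts 2-fluorophenyl in place of 3-chlorophenyl on an amine nitrogen. Going by the values given here, the one measured step that bears on this is an at least 1.6-fold lower number from compound 1 to compound 2 (0.22 log units; that floor lies within the scatter), which replaced 2-methylphenyl with 3-chlorophenyl. With so little evidence, only a small shift toward weaker inhibition is expected, namely a 1.4-fold higher number from compound 2 to compound 3 (0.13 log units; within the scatter). Compound 3 is estimated at 16000 nM, with an expected range of 7000 nM to 35000 nM.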

Compound 3, half-maximal inhibitory concentration: > 20000 nM
Compound 3: a limit, no number (the forecaster's own chance of this, stated with the estimate: 40%); middle value at least 1.2-fold (0.09 log units) away from the limit.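

The 2-fluorophenyl swap on this amine nitrogen yields a limit and not a number, leaving only a floor, an at least 1.6-fold higher number from compound 2 to compound 3 (0.22 log units; that floor lies within the scatter), so no loss beyond the scatter is shown. The step between the two limit compounds, compound 1 and compound 3, cannot be read. Compound 2, with 3-chlorophenyl, remains the only compound with an actual number, and compound 3 joins compound 1 at the limit: the limit of > 20000 nM in this assay, at which 2 of the 3 values shown sit.

Still open, going by these compounds, is whether the identity of the halogen or its place on the ring separates compound 2 from compound 3. A 3-fluorophenyl or 2-chlorophenyl group on the same amine nitrogen would separate the two.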